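The source may hold more compounds than are shown below. What is called first, only, known or untested is meant among the compounds shown, and "the series" means these compounds.

Compound 3 `Cc1ccc(CN2CCC(CCNC(=O)/C=C/c3cc(C(C)(C)C)c(O)c(C(C)(C)C)c3)CC2)cc1` belongs to a small set of hindered phenol amides that also includes compound 1 `CC(C)(C)c1cc(CCC(=O)NC2CCN(Cc3ccccc3)CC2)cc(C(C)(C)C)c1O` and compound 2 `CC(C)(C)c1cc(/C=C/C(=O)NCC2CCN(Cc3ccccc3)CC2)cc(C(C)(C)C)c1O`. In an assay on isolated protein for inhibition of Amine oxidase [flavin-containing] A (Homo sapiens), read by fluorescence, with stated times of 15 min and 20 min (a higher number here means a weaker inhibitor, a lower number a stronger inhibitor), compound 1 gives 90200 nM, compound 2 gives 48400 nM, and compound 3 gives 70100 nM. On these numbers compound 3 lies between the other two, but its value is within the scatter of compound 1 and also within the scatter of compound 2, so the three compounds cannot be told apart in this assay.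

Compound 4 `CC(C)(C)c1cc(/C=C/C(=O)NCCC2CCN(Cc3ccc(F)cc3F)CC2)cc(C(C)(C)C)c1O` has not yet been measured. It is derived from compound 3 by a single change: 2,4-difluorophenyl in place of 4-methylphenyl on a saturated chain carbon bound to an amine nitrogen in a ring. For the measured compounds named here, no pair among the measured compounds isolates a change of this kind, so there is no step to lean on. The three measured values sit close together, and the expected step from compound 3 to compound 4 is a 1.1-fold lower number from compound 3 to compound 4 (0.03 log units; within the scatter), none beyond the scatter. Compound 4 is therefore estimated at 65000 nM in this assay, with a range from 25000 nM to 160000 nM.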

Compound 4, half-maximal inhibitory concentration: 70600 nM
Compound 4: the middle estimate sits 1.1-fold (0.04 log units) below what was measured; the range from low to high includes it.
By their numbers in this assay, from the lowest: compounds 2, 3, 4 and 1 (each within the scatter of the next).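

In this assay, for the compounds shown here, 2,4-difluorophenyl in place of 4-methylphenyl on a saturated chain carbon bound to an amine nitrogen in a ring gives a 1.0-fold higher number from compound 3 to compound 4 (0.00 log units; within the scatter), the first step in this set that isolates a single change at this position. The swap removes the methyl group and brings in two fluorine atoms, yet the number stays within the scatter, so this pair shows no readable gain or loss from the change. No measurement shown here offers an explanation for this result.

From the compounds shown here alone, both groups compared are six-membered aromatic rings of carbon only, so it remains open whether a different group at this place, such as a pyridine ring, an amine or a carboxylic acid, would move the number beyond the scatter. Going by these compounds, it is also open whether this change would read the same on the chain of compound 2.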